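The source may hold more compounds than are shown below. What is called first, only, known or untested is meant among the compounds shown, and "the series" means these compounds.

Three compounds sharing one core have been examined in a functional assay on PC-3 cells (Homo sapiens) for inhibition, read by sulforhodamine B assay, with a stated time of 72 h; a higher number here means a weaker inhibitor, a lower number a stronger inhibitor. Compound 1 `Nc1sc(-c2ccc(Cl)cc2)c(-c2ccc(Cl)cc2)c1C(=O)N1CCCCC1` carries a piperidin-1-yl group on the carbonyl carbon, and in this assay compound 1 gives 14300 nM. Compound 2 `Nc1sc(-c2ccc(Cl)cc2)c(-c2ccc(Cl)cc2)c1C(=O)NC1CCCCC1` carries a cyclohexylamino group in that place, and in this assay compound 2 gives 7300 nM. Compound 3 `Nc1sc(-c2ccc(Cl)cc2)c(-c2ccc(Cl)cc2)c1C(=O)N1CCOCC1` carries a morpholin-4-yl group there, and in this assay compound 3 gives 11700 nM.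

Compound 2 holds the lowest of the three numbers, yet the step of a 2.0-fold lower number from compound 1 to compound 2 (0.29 log units; within the scatter) and the step of a 1.6-fold higher number from compound 2 to compound 3 (0.20 log units; within the scatter) both stay within the scatter, as does the step of a 1.2-fold lower number from compound 1 to compound 3 (0.09 log units; within the scatter); the three amides therefore cannot be ordered.

Compound 4 `Nc1sc(-c2ccc(Cl)cc2)c(-c2ccc(Cl)cc2)c1C(=O)N1CCNCC1` is not yet measured. It differs from compound 2 by piperazin-1-yl in place of cyclohexylamino on a carbonyl carbon. Every measured step exchanges one group on that same carbonyl carbon, and none moved this assay beyond the scatter. Since the piperazin-1-yl group, like piperidin-1-yl and morpholin-4-yl, joins the carbonyl through a ring nitrogen, the steps of a 2.0-fold lower number from compound 1 to compound 2 (0.29 log units; within the scatter) and a 1.6-fold higher number from compound 2 to compound 3 (0.20 log units; within the scatter) are the nearest guides, and both are small. Compound 4 is therefore expected to give about 10000 nM in this assay, between 4500 nM and 25000 nM, a step of a 1.4-fold higher number from compound 2 to compound 4 (0.14 log units; within the scatter) that is not expected to exceed the scatter.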

Compound 4, half-maximal inhibitory concentration: 2710 nM
Compound 4: the middle estimate sits 3.7-fold (0.57 log units) above what was measured, and the stated range ends above it.
By their numbers in this assay, from the lowest: compound 4; then compounds 2, 3 and 1 (each within the scatter of the next).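

On the carbonyl carbon, the earlier amides showed no step beyond the scatter in this assay, but piperazin-1-yl now stands apart from all three, with a 2.7-fold lower number from compound 2 to compound 4 (0.43 log units; beyond the scatter) and a 4.3-fold lower number from compound 3 to compound 4 (0.64 log units; beyond the scatter) and also a 5.3-fold lower number from compound 1 to compound 4 (0.72 log units; beyond the scatter) so that this position is shown to respond to the group it carries, if only modestly, and compound 4 is the strongest inhibitor of the four. Joining the carbonyl through a ring nitrogen does not by itself bring the lower number: compound 1 and compound 3 are joined in that way too, and they go against any such pattern. Nothing shown here accounts for the difference between piperazin-1-yl and the other groups.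

Going by these compounds, it remains open whether the lower number depends on the second ring nitrogen of piperazin-1-yl, and how a methyl or acetyl group on that nitrogen, or an open-chain aminoethyl amide, would read. The compounds shown also leave open whether the step would hold with other groups on the rest of the shared core, which stays the same in all four.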